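Arylsulfonyl in place of a small acyl group

This account rests on a few compounds, and the source may have more. Where it says the series, first, only, none or still open, it means among the compounds named here.

Measured in a functional assay on NCI-H1975 cells (Homo sapiens) for inhibition, read by sulforhodamine B assay, tested at 10 uM; on this read-out higher numbers stand for more inhibition at the one concentration tested (going by the name of the read-out) and lower numbers for less inhibition:
Compound 1 `COC(=O)CC(=O)N1N=C(c2ccc(N3CCN(C)CC3)cc2)CC1c1ccc(N(C)C)cc1`: -2.2%
Compound 2 `CN1CCN(c2ccc(C3=NN(C(=O)c4ccc(F)cc4)C(c4ccc(N(C)C)cc4)C3)cc2)CC1`: 32.2%
Compound 3 `Cc1ccc(S(=O)(=O)N2N=C(c3ccc(N4CCN(C)CC4)cc3)CC2c2ccc(N(C)C)cc2)cc1`: 38.1%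

Compound 1 has the lowest of these three numbers; compound 2 is nearest to it and compound 3 furthest. Compound 4 `CN1CCN(c2ccc(C3=NN(S(=O)(=O)c4ccc(Br)cc4)C(c4ccc(N(C)C)cc4)C3)cc2)CC1` is still to be measured in this assay. Its difference from compound 1: (4-bromophenyl)sulfonyl in place of ((methoxycarbonyl)methyl)carbonyl on an amine nitrogen in a ring. Among the compounds with values here, two measured steps bear on this change. Putting a 4-fluorophenyl on the carbonyl carbon gave a number 34.4 percentage points higher from compound 1 to compound 2 (beyond the scatter), and putting a (4-methylphenyl)sulfonyl on the ring nitrogen gave a number 40.3 percentage points higher from compound 1 to compound 3 (beyond the scatter); between those two, a number 5.9 percentage points higher from compound 2 to compound 3 (within the scatter). Within the data shown here, the closest precedent is compound 3, whose group is also a sulfonyl on an aromatic ring. For compound 4 a comparable large rise is expected, a number 40.2 percentage points higher from compound 1 to compound 4 (beyond the scatter). Compound 4 is therefore estimated at 38%, within 22% to 54%.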

Compound 4, a percentage reported as inhibition, at one concentration (the size of the read-out at that concentration, not a potency): 70.8%
Compound 4: middle estimate off by 32.8 percentage points, on the low side, outside the stated range (above it).
By their numbers in this assay, from the lowest: compound 1; then compounds 2 and 3 (each within the scatter of the next); then compound 4.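

A single atom change on the aromatic ring of the sulfonyl group counts for a great deal here: bromo in place of methyl gave a number 32.7 percentage points higher from compound 3 to compound 4 (beyond the scatter). The full replacement of the original acyl group gave a number 73 percentage points higher from compound 1 to compound 4 (beyond the scatter), and (4-bromophenyl)sulfonyl in place of (4-fluorophenyl)carbonyl gave a number 38.6 percentage points higher from compound 2 to compound 4 (beyond the scatter), so this position separates groups that compounds 2 and 3 left looking alike. No measured evidence explains why bromo has this effect. Still open, as far as these compounds go, is whether chloro or methoxy on that aromatic carbon would act like bromo, and whether a (4-bromophenyl)carbonyl group would keep the gain without the sulfonyl.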